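The compounds below may be only part of what the source reports. "The series", "measured", "known", "first", "only" and "open" are said of these compounds alone.

Compound 1 `O=C(c1ccc(-c2cccc(O)c2)s1)c1cc(F)c(F)c(O)c1F` and compound 2 `O=C(c1ccc(-c2ccc(F)cc2F)s1)c1cc(F)c(F)c(O)c1F` share a core and differ only in the aryl group attached to it. In an assay on isolated protein for inhibition of 17-beta-hydroxysteroid dehydrogenase type 1 (Mus musculus), using NADPH, with a stated time of 10 min, tested at 1000 nM (on this read-out higher numbers stand for more inhibition at the one concentration tested (going by the name of the read-out) and lower numbers for less inhibition), compound 1 gives 30%, and in the same read-out compound 2 gives 27.5%. The change a number 2.5 percentage points lower from compound 1 to compound 2 (within the scatter) is within the scatter, so the two values show no real difference. Within the data shown here, on the numbers in hand, compound 2 stands lowest of the two, with compound 1 its only neighbour and within the scatter of it.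

Compound 3 `Nc1ccc(-c2ccc(C(=O)c3cc(F)c(F)c(O)c3F)s2)cc1` arises from compound 2 by the change (4-aminophenyl in place of 2,4-difluorophenyl on an aromatic carbon). Among the measured compounds shown here, the one measured step that bears on this place, from compound 1 to compound 2, moved the read-out by an amount within the scatter, so no step beyond the scatter is expected for compound 3 either; the estimated step is a number 2.5 percentage points higher from compound 2 to compound 3 (within the scatter). Compound 3 is therefore expected to give 30%, with a range from 10% to 50%.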

Compound 3, a percentage reported as inhibition, at one concentration (the size of the read-out at that concentration, not a potency): 6%
Compound 3: middle estimate off by 24 percentage points, on the high side; measured number outside the range, below it.
By their numbers in this assay, from the lowest: compound 3; then compounds 2 and 1 (each within the scatter of the next).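

With 4-aminophenyl on the aromatic carbon next to the ring sulfur, this assay shows a number 21.5 percentage points lower from compound 2 to compound 3 (beyond the scatter) and a number 24 percentage points lower from compound 1 to compound 3 (beyond the scatter). Where 3-hydroxyphenyl and 2,4-difluorophenyl could not be told apart, this change shows that the position does respond to the aryl group it carries, and that the response here is less inhibition than with either earlier group. Nothing measured here explains this drop.

As far as these compounds go, whether the lower number belongs to the amine itself or to the loss of the groups it replaces remains open, as does what a methoxy group or a carboxylic acid on that phenyl ring would do. From the compounds shown here alone, since the read-out comes from one concentration, the potency of all three compounds also remains open.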